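Bromine on the Fused Ring: Compound 3 to Compound 4

The source may hold more compounds than are shown below. What is called first, only, known or untested is meant among the compounds shown, and "the series" means these compounds.

Measured so far in a functional assay on the whole organism (strain albino) with Rattus norvegicus as the target, in the maximal electroshock model, with a stated time of 1 h, at a dose of 30 mg/kg by the intraperitoneal route; on this read-out higher numbers stand for more inhibition at the one dose given (going by the name of the read-out) and lower numbers for less inhibition:

Compound 1, `Cc1nc2ccccc2c(=O)n1NCc1nnc(/N=C/c2ccc(O)cc2)s1`, gives 50%.
Compound 2, `Cc1nc2ccc(Br)cc2c(=O)n1NCc1nnc(/N=C/c2ccc(O)cc2)s1`, gives 50%.
Compound 3, `COc1ccc(C2SCC(=O)N2c2nnc(CNn3c(C)nc4ccccc4c3=O)s2)cc1`, gives 60%.

Compound 2 differs from compound 1 in one place: bromo in place of hydrogen on an aromatic carbon. That change made no change at the digits printed from compound 1 to compound 2 (within the scatter). Compound 3 carries a different core from compound 1, and the difference between the two cores is not broken down here. Of the three numbers, compound 3 stands highest, but its distance to compound 1 and to compound 2 lies within the scatter, so no order among the three can be read from them.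

Compound 4, `COc1ccc(C2SCC(=O)N2c2nnc(CNn3c(C)nc4ccc(Br)cc4c3=O)s2)cc1`, has not yet been measured. It differs from compound 3 by bromo in place of hydrogen on an aromatic carbon, which is the same change as that from compound 1 to compound 2, at the same place on the fused ring. This change occurs twice among the compounds shown. Among the compounds with values here, because the first instance gave no change at the digits printed from compound 1 to compound 2 (within the scatter), the expected step from compound 3 to compound 4 in this assay is likewise small: a number 2 percentage points lower from compound 3 to compound 4 (within the scatter). Compound 4 is thus estimated at 58%, expected to fall between 40% and 75%.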

Compound 4, a percentage reported as inhibition, in the whole organism at one dose (the size of the read-out at that dose, not a potency): 60%
Compound 4: the middle estimate sits 2 percentage points below what was measured, and the stated range covers the measured number.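

In this assay, putting bromo in place of hydrogen on the fused ring gave no change at the digits printed from compound 3 to compound 4 (within the scatter). Set beside the earlier case, the two steps do not differ: the same change on two cores in this assay, no change at the digits printed (within the scatter) from compound 1 to compound 2 and no change at the digits printed (within the scatter) from compound 3 to compound 4, 0 percentage points apart, within the scatter of two such steps Within these two pairs, then, the change carries from one core to the other with no step that stands out of the scatter, but this does not show that bromo and hydrogen are equivalent at this place, as a percentage at a single dose is not a potency and a real but small step could stay hidden in the scatter, and two cores cannot speak for every core in the series.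

The compounds shown carry only hydrogen or bromo at this place, which leaves open whether another group there, such as a nitrile or an amine, would shift the number. They also leave open whether bromo at another place on the fused ring would behave in the same way.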